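The source may hold more compounds than are shown below. What is called first, only, known or untested is meant among the compounds shown, and "the series" means these compounds.

Measured in a functional assay on the whole organism with Mus musculus as the target; on this read-out lower numbers stand for an effect already at smaller amounts and higher numbers for an effect only at larger amounts of compound:
Compound 1 `Cc1c(C)c2c(c(N)c1N)CC(C)(C)O2`: > 50 mg/kg, a limit
Compound 2 `Cc1c(C)c2c(c(C)c1N)CC(C)(CS(=O)(=O)c1ccccc1)O2`: 36.6 mg/kg
Compound 3 `CCC(=O)Nc1c(C)c(C)c2c(c1C)CC(C)(C)O2`: > 100 mg/kg, a limit

Compound 3 has no number in this small set: its result, > 100 mg/kg, is a limit of the assay. Compound 1 likewise has only a limit, > 50 mg/kg. Only compound 2 has a number, 36.6 mg/kg.

The next compound, compound 4 `CCCNc1c(C)c(C)c2c(c1C)CC(C)(C)O2`, differs from compound 3 in one place, with propyl in place of propanoyl on a nitrogen on an aromatic ring. Among the compounds with values here, no measured pair shows this change, so its size in this assay cannot be read directly. A step toward lower numbers is expected because compound 2 gives 36.6 mg/kg without a carbonyl on its nitrogen. Compound 1 goes against this reading, as it also lacks that carbonyl and yet reports only a limit. The expected change is an at least 2.2-fold lower number from compound 3 to compound 4 (0.34 log units; beyond the scatter). For compound 4 the estimated value is 45 mg/kg, with an expected range of 15 mg/kg to 120 mg/kg.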

Compound 4, dose for 50% inhibition: 51.1 mg/kg
Compound 4: middle estimate off by 1.1-fold (0.06 log units), on the low side, and the stated range covers the measured number.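

Within the data shown here, at this nitrogen on an aromatic ring, propyl in place of propanoyl gives an at least 1.9-fold lower number from compound 3 to compound 4 (0.29 log units; that floor lies within the scatter) in this assay and so yields the only step that can be read at this position. Compound 4 thus reaches a measured number on the shared core without the carbonyl, although the printed floor alone does not establish a change beyond the usual scatter. Going by these compounds, the true size of the step stays unknown because compound 3 has only a limit: the limit of > 100 mg/kg in this assay, at which 1 of the 4 values shown sits.

On these data alone, how far the real distance exceeds that floor remains open, as does the part played by the carbonyl itself apart from the change in the chain. Also open, as far as these compounds go, is how this nitrogen would respond to an ethyl group, a butyl group or a dimethylamino arrangement in place of propyl.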